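The source may report more compounds than this note shows. Statements on the series, on what has been measured and on what is new or still open speak of the compounds shown alone.

Compound 1, `CC(C)c1ccc(N2C(=O)C=CC2OCC(F)(F)F)cc1`: 6620 nM
Compound 2, `CCc1ccc(N2C(=O)C=CC2OCC(F)(F)F)cc1`: 4470 nM
Compound 3, `CC(C)(C)c1ccc(N2C(=O)C=CC2OCC(F)(F)F)cc1`: 70 nM

The three measured compounds share one core and differ only in the group on the aromatic ring. In a functional assay on K562 cells (Homo sapiens) for inhibition (on this read-out higher numbers stand for weaker inhibition and lower numbers for stronger inhibition), compound 3 gives the lowest of the three numbers; its nearest neighbour is compound 2, a 64-fold lower number from compound 2 to compound 3 (1.81 log units; beyond the scatter), and the furthest is compound 1, a 95-fold lower number from compound 1 to compound 3 (1.98 log units; beyond the scatter). By contrast the step between the isopropyl and ethyl groups, a 1.5-fold lower number from compound 1 to compound 2 (0.17 log units; within the scatter), is within the scatter.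

Compound 4, `O=C1C=CC(OCC(F)(F)F)N1c1ccc(Br)cc1`, is not yet measured. The change from compound 3 is bromo in place of tert-butyl on an aromatic carbon; the bromo group enters on an aromatic carbon of a six-membered aromatic ring of carbon only, para to a large group. Within the data shown here, no measured step contains a bromo group, so the only guide is what happens when the tert-butyl group is absent. Among the measured compounds shown here, two steps bear on this, a 64-fold lower number from compound 2 to compound 3 (1.81 log units; beyond the scatter) and a 95-fold lower number from compound 1 to compound 3 (1.98 log units; beyond the scatter), and both are large. Among the measured compounds the number drops sharply only with the tert-butyl group present. For compound 4 a large upward step in this assay is therefore expected, a 43-fold higher number from compound 3 to compound 4 (1.63 log units; beyond the scatter), with the size uncertain since a bromo group is neither ethyl nor isopropyl. The estimate for compound 4 is 3000 nM, within a range from 500 nM to 15000 nM.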

Compound 4, half-maximal inhibitory concentration: 3270 nM
Estimate against measurement, compound 4: 1.1-fold (0.04 log units) below, within the range that was stated.
By their numbers in this assay, from the lowest: compound 3; then compounds 4, 2 and 1 (each within the scatter of the next, the first and the last beyond it).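

In this assay the bromo group does not stand in for the tert-butyl group on this aromatic carbon (a 47-fold higher number from compound 3 to compound 4 (1.67 log units; beyond the scatter)), so the low number of compound 3 now stands apart from a third group, a halogen, and not only from the two smaller alkyl groups. Among these compounds, compound 4 falls within the scatter of the ethyl compound (a 1.4-fold lower number from compound 2 to compound 4 (0.14 log units; within the scatter)) and a modest step from the isopropyl compound (a 2.0-fold lower number from compound 1 to compound 4 (0.31 log units; beyond the scatter)), which leaves the tert-butyl group as the only one of the four groups here that goes with a low number. Nothing among the data at hand accounts for this gap between compound 3 and the other three compounds.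

The compounds shown leave open whether the low number belongs to the tert-butyl group alone or is shared by other branched groups on this aromatic carbon, such as a trimethylsilyl or a 1-methylcyclopropyl group. They also leave open what a trifluoromethyl group, an amine or a carboxylic acid would give there, and whether the tert-butyl group keeps its large step when the trifluoroethoxy chain on the shared core is replaced by a methoxy group.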